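Replacing the 2-methoxyethyl group of compound 1 with 1,1-difluoroethyl

A few compounds are considered here, and "the series" means these few. Any claim that something is new, unique, unknown or untested is made for them only; others in the source may bear on it.

Going by the values given here, only two compounds have been measured so far in an in vitro ADME assay on microsomes from liver (Mus musculus) for metabolic stability; a lower number here means slower removal, a higher number faster removal of the compound. Compound 1 (`COCCc1nc2nc(C)cc(Nc3ccc(S(F)(F)(F)(F)F)cc3)n2n1`) gives 14.1 mL.min-1.g-1, and compound 2 (`CCOc1nc2nc(C)cc(Nc3ccc(C(F)(F)F)cc3)n2n1`) gives 14.4 mL.min-1.g-1. These values lie within the scatter of each other, so compound 1 stands level with compound 2 on the available numbers, and neither can be separated from the other. The next compound to be tested is compound 3 (`Cc1cc(Nc2ccc(S(F)(F)(F)(F)F)cc2)n2nc(C(C)(F)F)nc2n1`). It carries 1,1-difluoroethyl in place of 2-methoxyethyl on an aromatic carbon of a five-membered aromatic ring with 3 nitrogen, between two ring nitrogen atoms (1,1-difluoroethyl in place of 2-methoxyethyl on an aromatic carbon). The rest of the structure of compound 1 is kept. Among the compounds with values here, no measured pair shows this change on its own, so the expectation rests on the structural change alone and is uncertain. A step beyond the scatter is expected in this assay, towards a lower number and so slower removal. The estimated step is a 3.5-fold lower number from compound 1 to compound 3 (0.55 log units; beyond the scatter). For compound 3 the expected value is 4 mL.min-1.g-1, with an estimated range from 1.5 mL.min-1.g-1 to 11 mL.min-1.g-1.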

Compound 3, intrinsic clearance in microsomes: 8.1 mL.min-1.g-1
The estimate for compound 3 lay 2.0-fold (0.31 log units) below the measured number; the range from low to high includes it.
By their numbers in this assay, from the lowest: compounds 3, 1 and 2 (each within the scatter of the next).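

In this assay, going by these compounds alone, the first pair of compounds that differ in one place gives a 1.7-fold lower number from compound 1 to compound 3 (0.24 log units; within the scatter) and this step lies within the scatter, so the two compounds cannot be separated on this read-out. On an aromatic carbon of a five-membered aromatic ring with 3 nitrogen, 1,1-difluoroethyl can therefore take the place of 2-methoxyethyl without a difference that can be resolved here, although a chain carrying oxygen leaves and a chain carrying fluorine enters. No supporting measurement bears on why the two groups read alike.

Going by these compounds, it remains open whether any group at this position can give a step beyond the scatter, and a cyclopropyl ring, a hydroxyl-bearing chain or an amine on the same core would each test that against 2-methoxyethyl. On these data alone, it is also open whether 1,1-difluoroethyl and 2-methoxyethyl would read alike on a different core, and compound 2 cannot answer this, as it differs from compound 1 in more than one place.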